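The source may hold more compounds than are shown below. What is called first, only, known or untested is meant among the compounds shown, and "the series" means these compounds.

Measured compounds in an assay on isolated protein for inhibition of Nicotinamide phosphoribosyltransferase (Homo sapiens), read by fluorescence, with stated times of 5 min and 15 min; on this read-out lower numbers stand for stronger inhibition and higher numbers for weaker inhibition:
- compound 1 `O=C(CCCCCCCN(Cc1ccc(F)cc1)c1ncc(C(=O)NCCCn2ccnc2)s1)NO`: 18 nM
- compound 2 `O=C(/C=C/c1ccc(CN(Cc2ccc(F)cc2)c2ncc(C(=O)NCCCn3ccnc3)s2)cc1)NO`: 14 nM
- compound 3 `O=C(CCCCCN(Cc1ccc(F)cc1)c1ncc(C(=O)NCCCn2ccnc2)s1)NO`: 7 nM

Compound 3 gives the lowest of the three numbers in this assay; its separation from compound 2 lies within the scatter, and only its separation from compound 1 lies beyond it, so compound 3 cannot be called the strongest inhibitor on these numbers alone.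

Compound 4 `O=C(NO)c1ccc(CN(Cc2ccc(F)cc2)c2ncc(C(=O)NCCCn3ccnc3)s2)cc1` differs from compound 3 by 4-(hydroxycarbamoyl)phenyl in place of 4-(hydroxycarbamoyl)butyl on a saturated chain carbon bound to a nitrogen on an aromatic ring. Within the data shown here, two measured steps bear on this change. The closest is a 2.0-fold lower number from compound 2 to compound 3 (0.30 log units; within the scatter), which exchanged an aromatic hydroxamate-bearing arm for a saturated one and stayed within the scatter. Further off, a 1.3-fold lower number from compound 1 to compound 2 (0.11 log units; within the scatter) made the reverse kind of swap on a longer saturated arm and also stayed within the scatter. Compound 4 has no measured partner differing only by the ethenyl spacer; compound 2 is the nearest point and gives 14 nM.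

Taken together, the hydroxamate arm has tolerated both aromatic and saturated forms without a step beyond the scatter, so no step beyond the scatter is expected for a 2.1-fold higher number from compound 3 to compound 4 (0.33 log units; beyond the scatter), with any drift more likely towards a slightly higher number. Compound 4 is therefore estimated at 15 nM in this assay, within a range of 5 nM to 45 nM.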

Compound 4, half-maximal inhibitory concentration: 14 nM
Compound 4: the middle estimate sits 1.1-fold (0.03 log units) above what was measured; the measured number falls inside the stated range.
By their numbers in this assay, from the lowest: compounds 3, 2, 4 and 1 (each within the scatter of the next, the first and the last beyond it).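

In this assay, the direct exchange of 4-(hydroxycarbamoyl)butyl for 4-(hydroxycarbamoyl)phenyl, on a saturated chain carbon bound to a nitrogen on an aromatic ring, gives a 2.0-fold higher number from compound 3 to compound 4 (0.30 log units; within the scatter) and so stays inside the scatter. Hydroxycarbamoyl in place of 2-(hydroxycarbamoyl)ethenyl on an aromatic carbon gives no change at the digits printed from compound 2 to compound 4 (within the scatter) and the exchange of the 6-(hydroxycarbamoyl)hexyl arm for the 4-(hydroxycarbamoyl)phenyl arm gives a 1.3-fold lower number from compound 1 to compound 4 (0.11 log units; within the scatter) so this position now shows no step beyond the scatter for an aromatic arm, with or without the ethenyl unit. No supporting data offer an explanation for this tolerance.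

From the compounds shown here alone, all four compounds carry hydroxycarbamoyl, so the effect of a carboxylic acid or a primary amide at the end of this arm remains open. Also open, going by these compounds, is how a chain shorter than 4-(hydroxycarbamoyl)butyl would read out.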